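The source may hold more compounds than are shown below. What is called first, only, known or untested is meant among the compounds shown, and "the series" means these compounds.

Measured compounds:

Compound 1, `CCN(Cc1ccoc1)C(=O)COc1ccc(C)cc1`: in an assay on HEK293 cells for agonist activity at transient receptor potential cation channel subfamily M member 8 (Homo sapiens), read by fluorescence and calcium flux, with a stated time of 15 min (a higher number here means that more compound is needed for the effect, a lower number that less compound is needed), compound 1 gives 136 nM.
Compound 2, `COc1ccc2oc(C(=O)N(Cc3cccs3)c3ccn[nH]3)cc2c1`: in this assay compound 2 gives 1.1 nM.
Compound 3, `Cc1ccc(OCC(=O)N(Cc2cccs2)c2c[nH]nc2C)cc1`: in this assay compound 3 gives 0.4 nM.

Of these three numbers, compound 1 stands highest. The nearest to it is compound 2, and the gap between the two lies well beyond the scatter; the furthest is compound 3, whose gap from compound 1 is larger still. Among the compounds with values here, compounds 2 and 3 share a different amide nitrogen substituent and a thiophene-bearing chain, so no single-change step connects either of them to compound 1.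

The unmeasured compound 4, `CCN(Cc1ccco1)C(=O)COc1ccc(C)cc1`, keeps all the atoms of compound 1 and rearranges one group: furan-2-yl in place of furan-3-yl on a saturated chain carbon bound to an amide-type nitrogen. Within the data shown here, no measured pair shows what this swap of furan isomers does on this scaffold, and the other two compounds carry no furan at all. With nothing to anchor a direction, the expected step from a 1.0-fold lower number from compound 1 to compound 4 (0.02 log units; within the scatter) is none beyond the scatter. Compound 4 is therefore estimated at 130 nM in this assay, with a range from 45 nM to 400 nM.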

Compound 4, half-maximal effective concentration: 489 nM
Compound 4: middle estimate off by 3.8-fold (0.58 log units), on the low side; measured number above the stated range.
By their numbers in this assay, from the lowest: compound 3; then compound 2; then compound 1; then compound 4.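

Exchanging furan-3-yl for furan-2-yl on a saturated chain carbon bound to an amide-type nitrogen is not a neutral swap in this assay: it gives a 3.6-fold higher number from compound 1 to compound 4 (0.56 log units; beyond the scatter), a modest step but one beyond the scatter. The two groups match in heavy atoms, hydrogen-bond donors, hydrogen-bond acceptors and charge, so this position separates two isomers that those counts do not tell apart. Nothing measured here offers a reason for the step.

The compounds shown leave open how a phenyl or pyridine ring would fare in place of either furan on this chain. On these data alone, it is also open whether furan-3-yl would still give the lower number on another core, since compound 2 and compound 3 carry no furan.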